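This account rests on a few compounds, and the source may have more. Where it says the series, first, only, none or still open, it means among the compounds named here.

Series notes. The shared core carries a variable group on an aromatic carbon: bromo in compound 1 `Brc1cn2ccnc2c(-c2ccc3ncn(C4CCCCC4)c3c2)n1`, phenyl in compound 2 `c1ccc(-c2cn3ccnc3c(-c3ccc4ncn(C5CCCCC5)c4c3)n2)cc1`, thiophen-3-yl in compound 3 `c1cn2cc(-c3ccsc3)nc(-c3ccc4ncn(C5CCCCC5)c4c3)c2n1`. In a functional assay on Hs-578T cells (Homo sapiens) for inhibition, read by sulforhodamine B assay, with a stated time of 48 h, tested at 10 uM (a higher number here means more inhibition at the concentration tested (going by the name of the read-out), a lower number less inhibition), compound 1 gives 16.1%, compound 2 gives 23.8% and compound 3 gives 5.56%. Compound 3 thus stands lowest of the three numbers, compound 1 nearest and compound 2 furthest. Within the set, a number 7.7 percentage points higher from compound 1 to compound 2 (within the scatter), whereas a number 10.5 percentage points lower from compound 1 to compound 3 (beyond the scatter) and a number 18.2 percentage points lower from compound 2 to compound 3 (beyond the scatter).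

Compound 4 `Clc1ccc(-c2cn3ccnc3c(-c3ccc4ncn(C5CCCCC5)c4c3)n2)cc1` is the next member: 4-chlorophenyl in place of thiophen-3-yl on an aromatic carbon. The 4-chlorophenyl entering is, like the phenyl of compound 2, a six-membered aromatic ring of carbon only, so the step from compound 2 to compound 3 bears most directly on it; run backwards it points to a gain of about that size. The step from compound 1 to compound 3 points the same way. A modest rise in this assay is therefore expected, bringing compound 4 back toward the number of compound 2. For compound 4 the expected step is a number 16.4 percentage points higher from compound 3 to compound 4 (beyond the scatter). The estimate for compound 4 in this assay is 22%, with a range from 8% to 38%.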

Compound 4, a percentage reported as inhibition, at one concentration (the size of the read-out at that concentration, not a potency): 6.35%
Beside the measured number, compound 4's estimate is 15.7 percentage points above it; measured number below the stated range.
By their numbers in this assay, from the lowest: compounds 3, 4, 1 and 2 (each within the scatter of the next, the first and the last beyond it).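

In this assay, a single chloro in place of hydrogen on an aromatic carbon of the phenyl group is enough to separate compound 4 from the phenyl member (a number 17.5 percentage points lower from compound 2 to compound 4 (beyond the scatter)). A shared six-membered aromatic ring of carbon only therefore does not place the two together at this position, while the 4-chlorophenyl and thiophen-3-yl groups cannot be told apart (a number 0.8 percentage points higher from compound 3 to compound 4 (within the scatter)), nor can the 4-chlorophenyl and bromo groups (a number 9.8 percentage points lower from compound 1 to compound 4 (within the scatter)). No measurement offered here accounts for the result.

Open, from the compounds shown here alone, is whether a chloro elsewhere on the phenyl group would give the same step. Also open, going by these compounds, is how an amine, a carboxylic acid or a longer alkyl chain on this aromatic carbon would read in this assay.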